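The source may hold more compounds than are shown below. What is called first, only, known or untested is meant among the compounds shown, and "the series" means these compounds.

In a functional assay on A2780 cells (Homo sapiens) for cytotoxicity, read by MTT assay, with a stated time of 24 h (on this read-out lower numbers stand for stronger inhibition and higher numbers for weaker inhibition), compound 1 `CC[C@H](C)[C@@H](NC(=O)Cn1cc(C2=C(c3c[nH]c4ccccc34)C(=O)N(C)C2=O)c2ccccc21)C(=O)OC` gives > 100000 nM, which is a limit and not a number. This places compound 1 at the limit of > 100000 nM in this assay, at which 1 of the 3 values shown sits, the weak end of what has been measured. Compound 2 `COC(=O)[C@H](NC(=O)Cn1cc(C2=C(c3c[nH]c4ccccc34)C(=O)N(C)C2=O)c2ccccc21)[C@@H](C)O` gives 21400 nM, and compound 3 `COC(=O)CCNC(=O)Cn1cc(C2=C(c3c[nH]c4ccccc34)C(=O)N(C)C2=O)c2ccccc21` gives 44500 nM.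

Compound 4 `COC(=O)[C@H](NC(=O)Cn1cc(C2=C(c3c[nH]c4ccccc34)C(=O)N(C)C2=O)c2ccccc21)C(C)C` makes a very small edit to compound 1, turning sec-butyl into isopropyl: hydrogen in place of methyl on a saturated chain carbon, three bonds along the chain from an amide-type nitrogen and a carbonyl carbon. Among the measured compounds shown here, no measured step makes this exact change, so the nearest guides are larger edits of the same side chain. Replacing ethyl with hydroxy gives an at least 4.6-fold lower number from compound 1 to compound 2 (0.66 log units; beyond the scatter), and replacing the whole 1-(methoxycarbonyl)-2-methylbutyl group gives an at least 2.2-fold lower number from compound 1 to compound 3 (0.35 log units; beyond the scatter). Both moved toward lower numbers, but because compound 1 is only a limit, neither size is exact. Losing one methyl is a smaller edit, so only a small shift toward lower numbers is expected, and compound 4 may well remain at the limit. The expected change is an at least 1.5-fold lower number from compound 1 to compound 4 (0.18 log units; that floor lies within the scatter). For compound 4 the estimated value is 65000 nM, with an expected range of 30000 nM to 100000 nM.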

Compound 4, half-maximal inhibitory concentration: 23800 nM
The estimate for compound 4 lay 2.7-fold (0.44 log units) above the measured number; measured number outside the range, below it.
By their numbers in this assay, from the lowest: compounds 2, 4 and 3 (each within the scatter of the next, the first and the last beyond it). At a limit, above all of these: compound 1.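

In this assay, changing sec-butyl to isopropyl, which swaps one methyl for hydrogen, gives an at least 4.2-fold lower number from compound 1 to compound 4 (0.62 log units; beyond the scatter), so this single methyl is enough to move the compound off the limit. Compound 1 remains a limit, so this step gives only a floor for the size of the change: the limit of > 100000 nM in this assay, at which 1 of the 4 values shown sits. Compound 4 cannot be separated from either of its closest comparators, with a 1.1-fold higher number from compound 2 to compound 4 (0.05 log units; within the scatter) and a 1.9-fold lower number from compound 3 to compound 4 (0.27 log units; within the scatter), so on this read-out isopropyl and 1-hydroxyethyl perform alike on the saturated chain carbon bound to the amide-type nitrogen and the carbonyl carbon.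

The compounds shown leave open how a benzyl group or an aminobutyl chain would behave on that same carbon. They also leave open what a carboxylic acid in place of the methyl ester would do.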